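Series notes: outlook for compound 4

The source may hold more compounds than are shown below. What is called first, only, known or untested is meant among the compounds shown, and "the series" means these compounds.

Compound 1 `CC/N=C(/N)Nc1nc(-c2ccc(OC)cc2)c(-c2ccc(OC)cc2)s1`: in a functional assay with Oryctolagus cuniculus as the target (on this read-out lower numbers stand for stronger inhibition and higher numbers for weaker inhibition), compound 1 gives only a limit, > 100 nM.
Compound 2 `COc1ccc(-c2nc(/N=C(\N)NC(C)C)sc2-c2ccc(OC)cc2)cc1`: in this assay compound 2 gives only a limit, > 100 nM.
Compound 3 `COc1ccc(-c2nc(CNC(=O)c3cccnc3)sc2-c2ccc(OC)cc2)cc1`: in this assay compound 3 gives 25 nM.
Compound 4 `COc1ccc(-c2nc(C(=O)N=C(N)N)sc2-c2ccc(OC)cc2)cc1`: not yet measured.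

Compound 2 sits at a limit, as does compound 1, so a step that the two limits leave unreadable from compound 1 to compound 2. Only compound 3 returns a number, and an at least 4.0-fold lower number from compound 2 to compound 3 (0.60 log units; beyond the scatter). The change to compound 4 is a group of 6 heavy atoms (2 carbon, 3 nitrogen, 1 oxygen; no ring) in place of a group of 7 heavy atoms (4 carbon, 3 nitrogen; no ring), on an aromatic carbon. Among the compounds with values here, no measured step shares this change; the single readable step, to compound 3, brings in a ring-bearing group that compound 4 does not carry. With two of three values at the limit of > 100 nM in this assay, at which 2 of the 3 values shown sit, the most likely outcome for compound 4 is another limit, and the step expected in this assay is small, a step that the limit leaves unreadable from compound 2 to compound 4. Compound 4 is therefore estimated at 150 nM, with a range of 50 nM to 600 nM.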

Compound 4, half-maximal inhibitory concentration: > 100 nM
Compound 4: no number, only a limit; the forecaster's own chance of this, stated with the estimate: 65%; the middle value is on the limit's open side.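

In this assay compound 4 gives only a limit, > 100 nM. At this position, the carbonyl-bearing group therefore joins the ring-free groups of compound 1 and compound 2 at the same limit, and the steps among these three cannot be read. The only readable new step is an at least 4.0-fold higher number from compound 3 to compound 4 (0.60 log units; beyond the scatter), and no ring-free group shown leaves the limit: the limit of > 100 nM in this assay, at which 3 of the 4 values shown sit.

The compounds shown do not separate the contribution of the ring in compound 3 from that of its amide link. A simple amine or a phenyl amide on this aromatic carbon would bear on that question.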